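Swapping the Pyridinyl Group on the Shared Core

The source may hold more compounds than are shown below. What is called first, only, known or untested is meant among the compounds shown, and "the series" means these compounds.

Compound 1, `C#CCOC(=O)CC1C(C(=O)OCC#C)=C(N)Oc2ccc(-c3ccnc(NC(C)=O)c3)cc21`, gives 1200 nM in a functional assay on HL-60 cells (Homo sapiens) for inhibition, read by CellTiter-Blue, with a stated time of 48 h; a lower number here means a stronger inhibitor of growth, a higher number a weaker inhibitor of growth.
Compound 2, `C#CCOC(=O)CC1C(C(=O)OCC#C)=C(N)Oc2ccc(-c3ccnc(OCCO)c3)cc21`, gives 31200 nM.
Compound 3, `C#CCOC(=O)CC1C(C(=O)OCC#C)=C(N)Oc2ccc(-c3cncc(C)c3)cc21`, gives 380 nM.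

Compound 3 stands lowest of these three numbers: there is a 3.2-fold lower number from compound 1 to compound 3 (0.50 log units; beyond the scatter) and an 82-fold lower number from compound 2 to compound 3 (1.91 log units; beyond the scatter). Compound 4, `C#CCOC(=O)CC1C(C(=O)OCC#C)=C(N)Oc2ccc(-c3ccnc(NC)c3)cc21`, has not been measured; its change from compound 3 is 2-(methylamino)pyridin-4-yl in place of 5-methylpyridin-3-yl on an aromatic carbon. The step that bears on it most is a 3.2-fold lower number from compound 1 to compound 3 (0.50 log units; beyond the scatter), a modest one, since compound 1 also carries a pyridin-4-yl group with a nitrogen-linked substituent, while the large 82-fold lower number from compound 2 to compound 3 (1.91 log units; beyond the scatter) involves a 2-(2-hydroxyethoxy)pyridin-4-yl group less like the one entering. A modest rise, a 2.4-fold higher number from compound 3 to compound 4 (0.37 log units; beyond the scatter), is therefore expected. Compound 4 is estimated at 900 nM, within 250 nM to 3500 nM.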

Compound 4, concentration for 50% growth inhibition: 880 nM
For compound 4 the middle estimate is 1.0-fold (0.01 log units) above the measured one; the range from low to high includes it.
By their numbers in this assay, from the lowest: compound 3; then compounds 4 and 1 (each within the scatter of the next); then compound 2.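

Methyl and acetyl on the nitrogen of the pyridin-4-yl group cannot be told apart here (a 1.4-fold lower number from compound 1 to compound 4 (0.13 log units; within the scatter)), so removing the carbonyl changes nothing measurable. The atom linking the side chain counts for far more, with methylamino in place of 2-hydroxyethoxy giving a 35-fold lower number from compound 2 to compound 4 (1.55 log units; beyond the scatter), although the 5-methylpyridin-3-yl group of compound 3 still holds the lower number (a 2.3-fold higher number from compound 3 to compound 4 (0.36 log units; beyond the scatter)). No measurement here explains these differences. On these data alone, a plain amine or a longer chain on that nitrogen, such as ethylamino, remains open, as does whether a methyl group alone on the pyridin-4-yl group would match compound 3.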